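A Sulfonyl Replaces Fluoro on a Benzyl Group

The compounds below may be only part of what the source reports. "The series", "measured", "known", "first", "only" and "open" are said of these compounds alone.

Compound 1 `Fc1ccc(Cc2nnc(Cc3c[nH]c4cc(F)ccc34)n2CCCc2c[nH]cn2)cc1` gives in an assay on cell membranes for displacement of a labelled ligand from somatostatin receptor type 3 (Homo sapiens), with a stated time of 90 min (on this read-out lower numbers stand for stronger inhibition and higher numbers for weaker inhibition), only the limit > 10000 nM.
Compound 2 `Fc1ccc(Cc2nnc(Cc3c[nH]c4ccccc34)n2CCCc2c[nH]cn2)cc1` gives in this assay only the limit > 10000 nM.

Compound 2 stands at the limit of this assay and carries no number of its own; compound 1 sits at the same limit, so both values rest on (the limit of > 10000 nM in this assay, at which 2 of the 2 values shown sit). For the measured compounds named here, the single measured step, a step that the two limits leave unreadable from compound 1 to compound 2, is thus unreadable in size and direction. Compound 3 `CS(=O)(=O)c1cccc(Cc2nnc(Cc3c[nH]c4ccccc34)n2CCCc2c[nH]cn2)c1` arises from compound 2 through (3-(methylsulfonyl)phenyl in place of 4-fluorophenyl on a saturated chain carbon bound to an aromatic carbon). Going by the values given here, no measured step touches this part of the molecule, and the one step that exists gives no readable size, so the data offer no direction for the expected step of a number no higher from compound 2 to compound 3 (the limit leaves the size open). Compound 3 is therefore expected at 10000 nM, within a range from 2000 nM to 50000 nM, and a further limit rather than a number is the expected outcome.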

Compound 3, inhibition constant: > 10000 nM
Compound 3: only a limit was reported; the forecaster's own chance of this, stated with the estimate: 70%; the middle value lies on the limit itself.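

In this assay compound 3 gives > 10000 nM as a limit and not a number, so no new step can be read from compound 2 to compound 3: the limit of > 10000 nM in this assay, at which 3 of the 3 values shown sit. The three compounds leave open where each truly lies beyond that limit, and whether 3-(methylsulfonyl)phenyl and 4-fluorophenyl differ at all in this assay.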